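From Methoxy to Chloro: an Expected Gain in Cytotoxicity

The source may report more compounds than this note shows. Statements on the series, on what has been measured and on what is new or still open speak of the compounds shown alone.

Of the compounds shown here, three on one shared core have been measured in a functional assay on L132 cells (Homo sapiens) for cytotoxicity, read by MTT assay, with a stated time of 72 h; on this read-out lower numbers stand for an effect already at smaller amounts and higher numbers for an effect only at larger amounts of compound. Compound 1 `O=C1/C(=C\c2ccc(O)cc2)c2ccccc2N1c1c(Cl)cccc1Cl` gives 30 ug/mL in this assay. Compound 2 `O=C1/C(=C\c2ccc(F)cc2)c2ccccc2N1c1c(Cl)cccc1Cl` gives 13 ug/mL, so that fluoro in place of hydroxy brought a 2.3-fold lower number from compound 1 to compound 2 (0.36 log units; beyond the scatter). Compound 3 `COc1ccc(/C=C2\C(=O)N(c3c(Cl)cccc3Cl)c3ccccc32)cc1` reaches only a limit of the assay, > 100 ug/mL, and no number is known for it. Compound 3 therefore sits at the limit of > 100 ug/mL in this assay, at which 1 of the 3 values shown sits. Against compound 1 the methyl on the oxygen gave an at least 3.3-fold higher number from compound 1 to compound 3 (0.52 log units; beyond the scatter), and against compound 2 the methoxy in place of fluoro gave an at least 7.6-fold higher number from compound 2 to compound 3 (0.88 log units; beyond the scatter).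

Compound 4 `O=C1/C(=C\c2ccc(Cl)cc2)c2ccccc2N1c1c(Cl)cccc1Cl` differs from compound 3 by chloro in place of methoxy on an aromatic carbon. Within the data shown here, two steps bear on this change: the halogen-bearing compound 2 stands far lower than compound 3, as an at least 7.6-fold higher number from compound 2 to compound 3 (0.88 log units; beyond the scatter) shows, and compound 2 also lies below compound 1 by a 2.3-fold lower number from compound 1 to compound 2 (0.36 log units; beyond the scatter). A chloro group in the same place is expected to move the number back down toward the region of compound 2, well beyond the scatter. Compound 4 is therefore estimated at 20 ug/mL, with a range from 8 ug/mL to 60 ug/mL, which would mean an expected step of an at least 5.0-fold lower number from compound 3 to compound 4 (0.69 log units; beyond the scatter).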

Compound 4, concentration for half-maximal effect: 9 ug/mL
Compound 4: middle estimate off by 2.2-fold (0.35 log units), on the high side, and the stated range covers the measured number.
By their numbers in this assay, from the lowest: compounds 4 and 2 (each within the scatter of the next); then compound 1. At a limit, above all of these: compound 3.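

In this assay the change from 4-methoxyphenyl to 4-chlorophenyl gives an at least 11-fold lower number from compound 3 to compound 4 (1.04 log units; beyond the scatter), and chloro also stands clear of hydroxy at this place, with a 3.3-fold lower number from compound 1 to compound 4 (0.52 log units; beyond the scatter). The two halogens, however, cannot be told apart at this position, with a 1.4-fold lower number from compound 2 to compound 4 (0.16 log units; within the scatter), while both lie clear of the hydroxy and methoxy compounds. The figure for compound 3 is a limit of the assay, so the step from it gives only a minimum size: the limit of > 100 ug/mL in this assay, at which 1 of the 4 values shown sits.

The compounds shown leave open whether a bromo or trifluoromethyl group at this place would stand with the two halogens, and whether an amine or a carboxylic acid there would stand with hydroxy or with methoxy. As far as these compounds go, with no number for compound 3, how far methoxy really lies from the other groups also remains unknown.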